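The source may report more compounds than this note shows. Statements on the series, on what has been measured and on what is new or still open speak of the compounds shown alone.

Compound 1 `O=C(Cc1cccnc1)c1cc2c(O)cccc2[nH]1` is the reference point. In an assay on isolated protein for inhibition of Indoleamine 2,3-dioxygenase 1 (Homo sapiens), read by spectrophotometry (on this read-out higher numbers stand for weaker inhibition and lower numbers for stronger inhibition), compound 1 gives 83000 nM, the highest of the three numbers shown; its nearest neighbour, compound 2 `COc1ccc2[nH]c(C(=O)Cc3cccnc3)cc2c1O`, gives 63000 nM, and compound 3 `O=C(Cc1cccnc1)c1cc2cc(Cl)ccc2[nH]1` gives 24600 nM. Among the measured compounds shown here, the only single-point step among the measured compounds, a 1.3-fold lower number from compound 1 to compound 2 (0.12 log units; within the scatter), brings methoxy in place of hydrogen on an aromatic carbon and stays within the scatter. Compound 4 `O=C(Cc1cccnc1)c1cc2c(F)cccc2[nH]1` differs from compound 1 by fluoro in place of hydroxy on an aromatic carbon. For the measured compounds named here, no measured step bears directly on this exchange: the step from compound 1 to compound 2 concerns a different group and is flat, while compound 3 carries chloro and differs from compound 1 in more than one place, so its lower number cannot be read as a guide to fluoro in place of hydroxy. With nothing to indicate a large shift, compound 4 is expected to move only modestly, by a step of a 1.7-fold lower number from compound 1 to compound 4 (0.22 log units; within the scatter) in this assay. The estimate for compound 4 in this assay is 50000 nM, with a range from 15000 nM to 160000 nM.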

Compound 4, half-maximal inhibitory concentration: 153000 nM
Beside the measured number, compound 4's estimate is 3.1-fold (0.49 log units) below it; low and high end bracket the measured number.
By their numbers in this assay, from the lowest: compound 3; then compounds 2, 1 and 4 (each within the scatter of the next, the first and the last beyond it).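

In this assay the exchange of fluoro for hydroxy gives a 1.8-fold higher number from compound 1 to compound 4 (0.27 log units; within the scatter) and is the first step shown that replaces the hydroxy itself. Hydroxy counts one hydrogen-bond donor and one hydrogen-bond acceptor and fluoro counts neither, yet at this position, ortho to a fused ring, the exchange does not carry the number beyond the scatter, so the read-out gives no sign here that the hydroxy is required. Nothing available explains this result.

The compounds shown leave open whether an amine, a methoxy or a carboxylic acid at this position would give a number beyond the scatter of compound 1. From the compounds shown here alone, compound 3 carries chloro but differs from compound 1 in more than one place, so the effect of chloro at this position also remains open.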